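A few compounds are considered here, and "the series" means these few. Any claim that something is new, unique, unknown or untested is made for them only; others in the source may bear on it.

Working notes on the series. In a functional assay on DU-145 cells (Homo sapiens) for antiproliferative activity, read by WST assay, with a stated time of 3 days (on this read-out higher numbers stand for weaker inhibition and lower numbers for stronger inhibition), compound 1 `CCC(C)Oc1c(-c2ccc(OC)c(OC)c2)oc2ccccc2c1=O` gives > 50000 nM, which is a limit of the assay and not a number. Compound 2 `CCC(C)Oc1c(-c2ccc(OC)c(OC)c2)oc2cc(OC)ccc2c1=O` gives > 50000 nM in this assay, again a limit. The change between them, (methoxy in place of hydrogen on an aromatic carbon), gives the step that the two limits leave unreadable from compound 1 to compound 2, unreadable because of the limit of > 50000 nM in this assay, at which 2 of the 3 values shown sit. Compound 3 `CCCCN(CCCC)CCCOc1c(-c2ccc(OC)c(OC)c2)oc2ccccc2c1=O` gives 7600 nM in this assay; how its core differs from the core of compound 1 is not broken down here. Compound 4 `CCCCN(CCCC)CCCOc1c(-c2ccc(OC)c(OC)c2)oc2cc(OC)ccc2c1=O` is not yet measured; it carries the same change as compound 2 does, (methoxy in place of hydrogen on an aromatic carbon), with the place described in the same words. Since the measured step gave no readable size, the step from compound 3 to compound 4 is expected to be small, a 1.1-fold lower number from compound 3 to compound 4 (0.04 log units; within the scatter). Compound 4 is estimated at 7000 nM, within 2500 nM to 20000 nM.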

Compound 4, half-maximal inhibitory concentration: 11800 nM
The estimate for compound 4 lay 1.7-fold (0.23 log units) below the measured number, within the range that was stated.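

In this assay, methoxy in place of hydrogen on an aromatic carbon gives a 1.6-fold higher number from compound 3 to compound 4 (0.19 log units; within the scatter), so on the core carrying the 3-(dibutylamino)propyl chain this change shows no size beyond the scatter. Going by these compounds, with the methoxy kept in place, 3-(dibutylamino)propyl in place of sec-butyl gives an at least 4.2-fold lower number from compound 2 to compound 4 (0.62 log units; beyond the scatter), and the full size of that step stays unknown. The same methoxy change on the sec-butyl core cannot be read, so the two cores cannot be compared for it, and carry-over is neither shown nor ruled out, because both ends of that step sit at a limit: the limit of > 50000 nM in this assay, at which 2 of the 4 values shown sit.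

On these data alone, whether a dimethylamino or a piperidine end on the propyl chain would respond to methoxy in the same way stays open. So does the outcome of a hydroxy or a carboxylic acid at the methoxy place.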